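Working notes: chloro in place of fluoro, compound 4

The compounds below may be only part of what the source reports. "The series", "measured", "known", "first", "only" and "open" are said of these compounds alone.

Measured in an ADME assay on MDBK cells (Bos taurus) for cytotoxicity; a lower number here means that less compound is tolerated, a higher number that more compound is tolerated:
compound 1 `Cc1cccc(Cn2ccc3nc(-c4ccccc4)nc-3c2)c1`: > 100000 nM
compound 2 `COc1ccccc1Cn1ccc2nc(-c3ccccc3)nc-2c1`: > 100000 nM
compound 3 `Fc1ccccc1Cn1ccc2nc(-c3ccccc3)nc-2c1`: > 100000 nM

Each of these entries is a limit and not a number. Compound 3 stands at > 100000 nM, which is a limit. Among the measured compounds shown here, it shares that position with compound 1 and compound 2, so the series so far shows (the limit of > 100000 nM in this assay, at which 3 of the 3 values shown sit).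

Compound 4 `Clc1ccccc1Cn1ccc2nc(-c3ccccc3)nc-2c1` differs from compound 3 by one substitution: chloro in place of fluoro on an aromatic carbon. This puts chloro in place of fluoro on an aromatic carbon, ortho to a large group.

The closest measured change is a step that the two limits leave unreadable from compound 2 to compound 3, where fluoro replaces methoxy on the same aromatic carbon. The other two measured changes are a step that the two limits leave unreadable from compound 1 to compound 3 and a step that the two limits leave unreadable from compound 1 to compound 2. None of them gives a size to carry over.

No step beyond the scatter and no direction is expected in this assay because of the limit of > 100000 nM in this assay, at which 3 of the 3 values shown sit. The expected step is a number no higher from compound 3 to compound 4 (the limit leaves the size open).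

For compound 4 the estimate is 100000 nM, with an expected range of 50000 nM to 200000 nM, and a report as a limit is again expected.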

Compound 4, half-maximal cytotoxic concentration: > 100000 nM
Compound 4: only a limit was reported (the forecaster's own chance of this, stated with the estimate: 85%); the middle value sits exactly at the limit.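

In this assay compound 4 gives > 100000 nM, which is a limit. No step between compound 4 and compound 1, compound 2 or compound 3 can be read: the limit of > 100000 nM in this assay, at which 4 of the 4 values shown sit.

The compounds shown leave open whether chloro, fluoro and methoxy differ at all in this assay.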